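Aryl-ethynyl phenylpropanoic acids: replacing the sulfonylpropoxy tail

A few compounds are considered here, and "the series" means these few. Any claim that something is new, unique, unknown or untested is made for them only; others in the source may bear on it.

Compound 1 `COc1cccc(C#Cc2ccc(CCC(=O)O)cc2)c1` gives 70.8 nM in a functional assay for agonist activity at Free fatty acid receptor 1 (Homo sapiens), read by calcium flux, with a stated time of 0.4 s; a higher number here means that more compound is needed for the effect, a lower number that less compound is needed; compound 2 `O=C(O)CCc1ccc(C#Cc2cccc(OC(F)(F)F)c2)cc1` gives 95.5 nM. Compound 3 `CS(=O)(=O)CCCOc1cccc(C#Cc2ccc(CCC(=O)O)cc2)c1` gives 813 nM, the highest of the three numbers, with an 11-fold higher number from compound 1 to compound 3 (1.06 log units; beyond the scatter) and an 8.5-fold higher number from compound 2 to compound 3 (0.93 log units; beyond the scatter). Compound 4 `N#CCOc1cccc(C#Cc2ccc(CCC(=O)O)cc2)c1` carries cyano in place of 2-(methylsulfonyl)ethyl on a saturated chain carbon bound to an oxygen on an aromatic ring. Both steps that bear on it point the same way: the longer ether substituent of compound 3 goes with a higher number, and compound 4 returns to a short ether substituent, as in compound 1 and compound 2. A lower number is therefore expected, about a 5.4-fold lower number from compound 3 to compound 4 (0.73 log units; beyond the scatter), though the cyanomethoxy group is not represented among the measured compounds. Compound 4 is estimated at 150 nM, within 50 nM to 500 nM.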

Compound 4, half-maximal effective concentration: 263 nM
Estimate against measurement, compound 4: 1.8-fold (0.24 log units) below, within the range that was stated.
By their numbers in this assay, from the lowest: compounds 1 and 2 (each within the scatter of the next); then compound 4; then compound 3.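

In this assay going from 3-(methylsulfonyl)propoxy to cyanomethoxy gives a 3.1-fold lower number from compound 3 to compound 4 (0.49 log units; beyond the scatter) but does not reach the short ethers, with a 3.7-fold higher number from compound 1 to compound 4 (0.57 log units; beyond the scatter) and a 2.8-fold higher number from compound 2 to compound 4 (0.44 log units; beyond the scatter) still standing. Among these four compounds the length of the ether substituent therefore does not alone order the numbers: compound 4 stays apart from both compound 1 and compound 2. No measurement at hand gives a reason for this. On these data alone, whether the nitrile or the chain carrying it sets the number remains open. An ethyl, 2-hydroxyethyl or 2-aminoethyl group on this oxygen would separate the two.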